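A Phenyl to tert-Butyl Swap at the Assay Limit

A few compounds are considered here, and "the series" means these few. Any claim that something is new, unique, unknown or untested is made for them only; others in the source may bear on it.

In a functional assay on HCT-116 cells (Homo sapiens) for cytotoxicity, read by MTT assay, with a stated time of 72 h (a higher number here means a weaker inhibitor, a lower number a stronger inhibitor), compound 1 (`O=C1CS/C(=N\c2csc(-c3ccccc3)c2)N1`) gives > 50000 nM as a limit, not a number. Compound 2 (`O=C1CS/C(=N\c2csc(-c3ccc(Cl)cc3)c2)N1`) likewise gives > 50000 nM as a limit. Within the data shown here, the only measured step is a step that the two limits leave unreadable from compound 1 to compound 2 and it offers no size to carry over, with the limit of > 50000 nM in this assay, at which 2 of the 2 values shown sit, as the sole evidence. Among the measured compounds shown here, in compound 3 (`CC(C)(C)c1cc(/N=C2/NC(=O)CS2)cs1`) tert-butyl stands in place of phenyl on an aromatic carbon (tert-butyl in place of phenyl on an aromatic carbon) and no measured step speaks to this change. In this assay no step beyond the scatter is therefore expected, and the estimated step is a step that the limit leaves unreadable from compound 1 to compound 3 with neither direction favoured. Compound 3 is expected at an estimated 60000 nM with a range of 25000 nM to 150000 nM around that figure.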

Compound 3, half-maximal inhibitory concentration: > 50000 nM
Compound 3 ended at the assay's limit (the forecaster's own chance of this, stated with the estimate: 80%); the middle value does not contradict the limit.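

Among these compounds, compound 1 and compound 3 both end at a limit, not a number, so no step between them can be read: the limit of > 50000 nM in this assay, at which 3 of the 3 values shown sit. The compounds shown leave open whether swapping phenyl for tert-butyl changes anything in this assay.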